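This account rests on a few compounds, and the source may have more. Where it says the series, first, only, none or still open, it means among the compounds named here.

Compound 1 `ClCc1ccc(Cn2cnc3c(Cl)ncnc32)cc1` — in a functional assay on IGROV-1 cells (Homo sapiens) for cytotoxicity, read by sulforhodamine B assay, with a stated time of 48 h (on this read-out higher numbers stand for lower toxicity in this test and lower numbers for higher toxicity in this test), compound 1 gives > 100000 nM, which is a limit of the test rather than a number.
Compound 2 `ClCc1cccc(Cn2cnc3c(Cl)ncnc32)c1` — in this assay compound 2 gives > 100000 nM, again a limit and not a number.

Going by the values given here, compound 2 stands only at a limit, and the one other measured value sits at the same place: the limit of > 100000 nM in this assay, at which 2 of the 2 values shown sit. Among the compounds with values here, no step between measured compounds can be followed here. Compound 3 `ClCc1cccc(Cn2cnc3c(Cl)nc(Cl)nc32)c1` differs from compound 2 by chloro in place of hydrogen on an aromatic carbon. Within the data shown here, with no measured step to lean on, the step from compound 2 to compound 3 is expected to be a number no higher from compound 2 to compound 3 (the limit leaves the size open), nothing beyond the usual scatter. Compound 3 is estimated at 100000 nM, in a range from 30000 nM to 300000 nM, with a real chance that only a limit is reported again.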

Compound 3, concentration lethal to 50% of the cells: 20000 nM
Beside the measured number, compound 3's estimate is 5.0-fold (0.70 log units) above it; the measured number lies below the stated range.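

In this assay, chloro in place of hydrogen on this aromatic carbon, between two ring nitrogen atoms, gives an at least 5.0-fold lower number from compound 2 to compound 3 (0.69 log units; beyond the scatter). Going by these compounds alone, this is the first sign that the position affects toxicity in this test, which compound 1 and compound 2 could not show. The true size of the step remains unknown because compound 2 stands only at a limit: the limit of > 100000 nM in this assay, at which 2 of the 3 values shown sit.

Going by these compounds, whether an amine or a methoxy group on this carbon would also lower the number stays open. So does whether the same change on compound 1 would do so.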